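This account rests on a few compounds, and the source may have more. Where it says the series, first, only, none or still open, it means among the compounds named here.

In a functional assay on A2780 cells (Homo sapiens) for antiproliferative activity, read by fluorescence, with a stated time of 72 h (on this read-out lower numbers stand for stronger inhibition and higher numbers for weaker inhibition), compound 1 (`CN1CCC(C(=O)N2Cc3c(NC(=O)C4CCC4)n[nH]c3C2(C)C)CC1`) gives 140 nM and compound 2 (`CN1CCC(C(=O)N2Cc3c(NC(=O)c4ccc(F)c(F)c4)n[nH]c3C2(C)C)CC1`) gives 100 nM while compound 3 (`CN1CCC(C(=O)N2Cc3c(NC(=O)c4cccc(F)c4)n[nH]c3C2(C)C)CC1`) gives 200 nM and so sits within the scatter of both. Compound 4 (`CCCNC(=O)Nc1n[nH]c2c1CN(C(=O)C1CCN(C)CC1)C2(C)C`) carries propylamino in place of 3-fluorophenyl on a carbonyl carbon. Changes on that carbonyl carbon are small so far: a 1.4-fold higher number from compound 1 to compound 3 (0.15 log units; within the scatter) and a 1.4-fold lower number from compound 1 to compound 2 (0.15 log units; within the scatter) are both within the scatter, as is a 2.0-fold higher number from compound 2 to compound 3 (0.30 log units; within the scatter) on an aromatic carbon. Within the data shown here, no measured compound carries propylamino, so this evidence is indirect, and no step beyond the scatter is expected in this assay for this change. The estimated step is no change at the digits printed from compound 3 to compound 4 (within the scatter) and no larger move is expected. Compound 4 is expected at 200 nM in a range of 70 nM to 550 nM by this estimate.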

Compound 4, half-maximal inhibitory concentration in the A2780 assay: 650 nM
The estimate for compound 4 lay 3.3-fold (0.51 log units) below the measured number, and the stated range ends below it.
By their numbers in the A2780 assay, from the lowest: compounds 2, 1 and 3 (each within the scatter of the next); then compound 4.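

In the A2780 assay, cyclobutyl, 3-fluorophenyl and 3,4-difluorophenyl on this carbonyl carbon stay within the scatter of each other, whereas propylamino gives steps beyond it: a 3.3-fold higher number from compound 3 to compound 4 (0.51 log units; beyond the scatter), a 6.5-fold higher number from compound 2 to compound 4 (0.81 log units; beyond the scatter) and a 4.6-fold higher number from compound 1 to compound 4 (0.67 log units; beyond the scatter). This position therefore does respond to the group it carries, and all three steps run towards weaker inhibition. In a physicochemical assay for solubility, at pH 7 (on this read-out higher numbers stand for higher solubility and lower numbers for lower solubility), compound 3 gives > 225000 nM, which is a limit of the assay. In the physicochemical assay compound 4 gives > 225000 nM, which is also a limit of the assay. In the physicochemical assay the step from compound 3 to compound 4 cannot be read, as both values are limits of the assay: the limit of > 225000 nM in the physicochemical assay, at which 2 of the 2 values shown sit.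

Still open, on these data alone, is whether the step in the A2780 assay goes with the nitrogen of propylamino or with its open chain. A plain butyl chain or a cyclobutylamino group on the same carbonyl carbon would separate the two.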